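Azole Exchange on a Shared Core in Rat Paw Edema

The source may hold more compounds than are shown below. What is called first, only, known or untested is meant among the compounds shown, and "the series" means these compounds.

Compound 1 `O=C(O)c1cc(-c2cncs2)ccc1O` gives a limit of > 200 mg/kg in a functional assay on the whole organism for inhibition, with Rattus norvegicus as the target, read by paw edema; a lower number here means that less compound is needed, a higher number that more compound is needed for the effect.
Compound 2 `O=C(O)c1cc(-c2cocn2)ccc1O` gives 110 mg/kg in this assay.
Compound 3 `O=C(O)c1cc(-c2ncco2)ccc1O` gives 100 mg/kg in this assay.

The value of compound 1 is a limit of the assay, not a number. Compound 3 gives the lower of the two numbers, though a 1.1-fold lower number from compound 2 to compound 3 (0.04 log units; within the scatter) leaves it within the scatter of compound 2; the steps of an at least 1.8-fold lower number from compound 1 to compound 2 (0.25 log units; that floor lies within the scatter) and an at least 2.0-fold lower number from compound 1 to compound 3 (0.30 log units; that floor lies within the scatter) are floors only. Compound 4 `O=C(O)c1cc(-n2ccnn2)ccc1O` differs from compound 3 by 1H-1,2,3-triazol-1-yl in place of 1,3-oxazol-2-yl on an aromatic carbon. Every measured step exchanges one five-membered ring for another on the same aromatic carbon, and none is shown beyond the scatter, so compound 4 is expected to show no step beyond the scatter in this assay, namely a 1.2-fold higher number from compound 3 to compound 4 (0.08 log units; within the scatter). Compound 4 is therefore estimated at 120 mg/kg, between 55 mg/kg and 260 mg/kg.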

Compound 4, dose for half-maximal effect: 150 mg/kg
Beside the measured number, compound 4's estimate is 1.3-fold (0.10 log units) below it; the range from low to high includes it.
By their numbers in this assay, from the lowest: compounds 3, 2 and 4 (each within the scatter of the next). At a limit, above all of these: compound 1.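

Placing 1H-1,2,3-triazol-1-yl on this aromatic carbon extends the exchange to a ring with 3 hetero atoms, and in this assay neither a 1.5-fold higher number from compound 3 to compound 4 (0.18 log units; within the scatter) nor a 1.4-fold higher number from compound 2 to compound 4 (0.13 log units; within the scatter) leaves the scatter. Compound 1 stands at a limit of the assay, not at a number: the limit of > 200 mg/kg in this assay, at which 1 of the 4 values shown sits. Its step to the new compound, an at least 1.3-fold lower number from compound 1 to compound 4 (0.12 log units; that floor lies within the scatter), is therefore a floor only. The compounds shown leave open whether something other than a five-membered aromatic ring at this place, such as an amine or a longer alkyl chain, would move the number beyond the scatter.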